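Shifting the fluorine: from compound 3 to compound 4

A few compounds are considered here, and "the series" means these few. Any claim that something is new, unique, unknown or untested is made for them only; others in the source may bear on it.

In a functional assay on K562 cells (Homo sapiens) for cytotoxicity, read by MTT assay, with a stated time of 48 h (a higher number here means a weaker inhibitor, a lower number a stronger inhibitor), compound 3 (`O=C(CN[C@H]1CCN(S(=O)(=O)Cc2ccccc2)C1)N1CCN(Cc2ccccc2F)CC1`) gives 12600 nM. That sits within the scatter of the two other measured analogues: compound 1 (`Cc1cccc(CN2CCN(C(=O)CN[C@H]3CCN(S(=O)(=O)Cc4ccccc4)C3)CC2)c1`) gives 11300 nM and compound 2 (`O=C(CN[C@H]1CCN(S(=O)(=O)Cc2ccccc2)C1)N1CCN(Cc2ccccc2Cl)CC1`) gives 9000 nM. Compound 4 (`O=C(CN[C@H]1CCN(S(=O)(=O)Cc2ccccc2)C1)N1CCN(Cc2ccc(F)cc2)CC1`) carries 4-fluorophenyl in place of 2-fluorophenyl on a saturated chain carbon bound to an amine nitrogen in a ring. Among the measured compounds shown here, no measured step tests this exact change, so the evidence is indirect. The steps of a 1.1-fold higher number from compound 1 to compound 3 (0.05 log units; within the scatter), a 1.4-fold higher number from compound 2 to compound 3 (0.15 log units; within the scatter) and a 1.3-fold lower number from compound 1 to compound 2 (0.10 log units; within the scatter) all stay within the scatter. No shift beyond the scatter is therefore expected in this assay, and the expected step is a 1.1-fold lower number from compound 3 to compound 4 (0.04 log units; within the scatter). The estimated value for compound 4 is 11500 nM, with an expected range of 6000 nM to 22000 nM.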

Compound 4, half-maximal inhibitory concentration: 14300 nM
The estimate for compound 4 lay 1.2-fold (0.09 log units) below the measured number; the measured number falls inside the stated range.
By their numbers in this assay, from the lowest: compounds 2, 1, 3 and 4 (each within the scatter of the next).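

Within this assay, the fluorine change from 2-fluorophenyl to 4-fluorophenyl gives a 1.1-fold higher number from compound 3 to compound 4 (0.05 log units; within the scatter), so this position has now been tested with the fluorine placed differently on the same group, and no shift beyond the scatter appears. The other comparisons give a 1.6-fold higher number from compound 2 to compound 4 (0.20 log units; within the scatter) and a 1.3-fold higher number from compound 1 to compound 4 (0.10 log units; within the scatter), so all four aryl groups at this position read alike. No supporting evidence bears on this flat result.

Still open, on these data alone, is whether an amine or a carboxylic acid on the phenyl group, or a longer chain at this position, would move the number beyond the scatter. Changes to the shared core also remain untested in the compounds shown here.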